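The source may hold more compounds than are shown below. What is called first, only, known or untested is meant among the compounds shown, and "the series" means these compounds.

Compound 1 `COc1ccc(Nc2nc(-c3cccc(F)c3)nc3ccc(F)cc23)cc1` is the only one of the three measured compounds for which a functional assay on COLO 205 cells (Homo sapiens) for cytotoxicity, read by MTT assay, with a stated time of 48 h (on this read-out lower numbers stand for stronger inhibition and higher numbers for weaker inhibition), returns a number: in this assay compound 1 gives 46800 nM. Compound 2 `Fc1ccc(Nc2nc(-c3cccc(F)c3)nc3ccc(F)cc23)cc1` reaches only the limit of this assay, > 50000 nM. Compound 3 `Nc1ccc(Nc2nc(-c3cccc(F)c3)nc3ccc(F)cc23)cc1` likewise stops at the limit, > 50000 nM. The steps from compound 1 are therefore floors, an at least 1.0-fold higher number from compound 1 to compound 2 (0.02 log units; that floor lies within the scatter) and an at least 1.0-fold higher number from compound 1 to compound 3 (0.02 log units; that floor lies within the scatter), and the step that the two limits leave unreadable from compound 2 to compound 3 cannot be read because both values sit at the limit of > 50000 nM in this assay, at which 2 of the 3 values shown sit.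

Compound 4 `Nc1cccc(Nc2nc(-c3cccc(F)c3)nc3ccc(F)cc23)c1` has not yet been measured in this assay; it differs from compound 1 by 3-aminophenyl in place of 4-methoxyphenyl on a nitrogen on an aromatic ring. Since both measured changes at this nitrogen left the number at or past the limit, compound 4 is expected to show a step of a 1.4-fold higher number from compound 1 to compound 4 (0.14 log units; within the scatter) toward weaker inhibition, or none beyond the scatter. Compound 4 is thus estimated at 65000 nM, between 30000 nM and 150000 nM, with a real chance that only a limit is reported.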

Compound 4, half-maximal inhibitory concentration: > 50000 nM
Compound 4 was reported as a limit (the forecaster's own chance of this, stated with the estimate: 60%); the middle value does not contradict the limit.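

In this assay, moving to 3-aminophenyl on this nitrogen gives an at least 1.0-fold higher number from compound 1 to compound 4 (0.02 log units; that floor lies within the scatter), so this change shows no loss that can be told from the scatter. Shifting the amino group's place on the ring, which the earlier compounds did not cover, still yields no number. The steps from compound 2 and compound 3 to compound 4 cannot be read, as these values stop at one limit: the limit of > 50000 nM in this assay, at which 3 of the 4 values shown sit.

On these data alone, it remains open whether 3-methoxyphenyl, a carboxylic acid on this ring or an alkyl chain in its place would read clearly lower than compound 1, which gives 46800 nM.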